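The source may report more compounds than this note shows. Statements on the series, on what has been measured and on what is new or still open speak of the compounds shown alone.

Compound 1 `O=c1[nH]/c(=N\OCCCc2ccc(Br)cc2)ccn1[C@@H]1O[C@H](COP(=O)(O)OP(=O)(O)OP(=O)(O)O)[C@@H](O)[C@H]1O`: 225 nM
Compound 2 `O=c1[nH]/c(=N\OCCCc2ccc([N+](=O)[O-])cc2)ccn1[C@@H]1O[C@H](COP(=O)(O)OP(=O)(O)OP(=O)(O)O)[C@@H](O)[C@H]1O`: 1330 nM
Compound 3 `O=c1[nH]/c(=N\OCCCc2ccsc2)ccn1[C@@H]1O[C@H](COP(=O)(O)OP(=O)(O)OP(=O)(O)O)[C@@H](O)[C@H]1O`: 164 nM

All values come from a functional assay on 1321-N1 cells for agonist activity at P2Y purinoceptor 6 (Homo sapiens), read by scintillation counting and inositol phosphate accumulation; a higher number here means that more compound is needed for the effect, a lower number that less compound is needed. Compound 3 gives the lowest number of the three, but a 1.4-fold lower number from compound 1 to compound 3 (0.14 log units; within the scatter) lies within the scatter, so compound 1 and compound 3 are not separated; only compound 2 stands apart, through a 5.9-fold higher number from compound 1 to compound 2 (0.77 log units; beyond the scatter) and an 8.1-fold lower number from compound 2 to compound 3 (0.91 log units; beyond the scatter).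

Compound 4 `O=c1[nH]/c(=N\OCCCc2ccc3ccccc3c2)ccn1[C@@H]1O[C@H](COP(=O)(O)OP(=O)(O)OP(=O)(O)O)[C@@H](O)[C@H]1O` differs from compound 3 by naphthalen-2-yl in place of thiophen-3-yl on a saturated chain carbon, three bonds along the chain from an oxygen. Going by the values given here, no measured step exchanges one aromatic group for a larger carbon-only one. The nearest comparison is the exchange of 4-bromophenyl for thiophen-3-yl, a 1.4-fold lower number from compound 1 to compound 3 (0.14 log units; within the scatter), which stayed within the scatter, whereas only the nitro-bearing compound 2 moved the number. For compound 4 the expected step is therefore a 1.1-fold lower number from compound 3 to compound 4 (0.04 log units; within the scatter), not beyond the scatter. Compound 4 is estimated at 150 nM, range 50 nM to 500 nM.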

Compound 4, half-maximal effective concentration: 90 nM
The estimate for compound 4 lay 1.7-fold (0.22 log units) above the measured number; low and high end bracket the measured number.
By their numbers in this assay, from the lowest: compounds 4, 3 and 1 (each within the scatter of the next, the first and the last beyond it); then compound 2.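

The position, on a saturated chain carbon, three bonds along the chain from an oxygen, accepts naphthalen-2-yl: a 1.8-fold lower number from compound 3 to compound 4 (0.26 log units; within the scatter) stays within the scatter, so thiophen-3-yl and this larger group of two aromatic carbon rings are not separated in this assay. Against the bromo-bearing group, there is a 2.5-fold lower number from compound 1 to compound 4 (0.40 log units; beyond the scatter), beyond the scatter, and against the nitro-bearing group, a 15-fold lower number from compound 2 to compound 4 (1.17 log units; beyond the scatter), the widest gap in the series. No available evidence explains these differences.

Open, going by these compounds, is whether a saturated cyclohexyl group, an amine on the aromatic ring or a longer chain would keep the number this low.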